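The compounds below may be only part of what the source reports. "The series", "measured", "known", "first", "only" and "open" are said of these compounds alone.

Compound 2 `CCNC(=O)N1CCC[C@H]1C(=O)N1CCC(NS(=O)(=O)c2cc(S(=O)(=O)c3ccccc3)ccc2C(F)(F)F)CC1` stands at the lowest number of the two measured in an assay on isolated protein for binding affinity to secreted frizzled-related protein 1 (Homo sapiens), read by fluorescence (a lower number here means a stronger inhibitor, a higher number a weaker inhibitor), at 30 nM. Its nearest neighbour is compound 1 `O=C([C@@H]1CCCN1C(=O)c1ccncc1)N1CCC(NS(=O)(=O)c2cc(S(=O)(=O)c3ccccc3)ccc2C(F)(F)F)CC1`, which in this assay gives 70 nM; the step of a 2.3-fold lower number from compound 1 to compound 2 (0.37 log units; beyond the scatter) is the only measured one so far, and it concerns a different place, the group on a carbonyl carbon. The next compound, compound 3 `CC(C)(C)NC(=O)N1CCC[C@H]1C(=O)N1CCC(NS(=O)(=O)c2cc(S(=O)(=O)c3ccccc3)ccc2C(F)(F)F)CC1`, keeps that urea and changes only the alkyl on its nitrogen: tert-butyl in place of ethyl on an amide-type nitrogen. Among the compounds with values here, no measured pair alters the group on that amide-type nitrogen, so nothing in hand bears directly on this step; the one step measured touched the carbonyl carbon, not the nitrogen substituent. With no evidence either way, no shift beyond the scatter is expected, no change at the digits printed from compound 2 to compound 3 (within the scatter). Compound 3 is therefore estimated at 30 nM in this assay, with a range from 12 nM to 75 nM.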

Compound 3, half-maximal inhibitory concentration in the secreted frizzled-related protein 1 assay: 20 nM
Compound 3: the middle estimate sits 1.5-fold (0.18 log units) above what was measured, and the stated range covers the measured number.
By their numbers in the secreted frizzled-related protein 1 assay, from the lowest: compounds 3 and 2 (each within the scatter of the next); then compound 1.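

In the secreted frizzled-related protein 1 assay, compound 2 gives 30 nM and compound 3 gives 20 nM; tert-butyl in place of ethyl on an amide-type nitrogen gives a 1.5-fold lower number from compound 2 to compound 3 (0.18 log units; within the scatter), so this position does not separate the two alkyl groups in this read-out. The wider replacement on a carbonyl carbon, (tert-butyl)amino in place of pyridin-4-yl, gives a 3.5-fold lower number from compound 1 to compound 3 (0.54 log units; beyond the scatter), a step beyond the scatter that adds to the earlier ethylamino result of a 2.3-fold lower number from compound 1 to compound 2 (0.37 log units; beyond the scatter). In a physicochemical assay for solubility (a higher number here means a more soluble compound, a lower number a less soluble compound), compound 2 gives 100000 nM and compound 3 gives 50000 nM; the tert-butyl for ethyl change gives a 2.0-fold lower number from compound 2 to compound 3 (0.30 log units; within the scatter), so it does not separate the two compounds here either.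

Nothing at hand explains these numbers. Still open, from the compounds shown here alone, is whether a phenyl ring, or a longer chain ending in an amine or a carboxylic acid, on that nitrogen would hold the number in the secreted frizzled-related protein 1 assay.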